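The source may hold more compounds than are shown below. What is called first, only, known or untested is meant among the compounds shown, and "the series" means these compounds.

Of the compounds shown here, three sharing one core have been measured in a physicochemical assay for lipophilicity; on this read-out higher numbers stand for higher lipophilicity and lower numbers for lower lipophilicity. Compound 1 `C[n+]1ccn(COCCCS(C)(=O)=O)c1/C=N/O` gives -2.5, compound 2 `C[n+]1ccn(COCCS(=O)(=O)c2ccccc2)c1/C=N/O` gives -2.39, and compound 3 `C[n+]1ccn(COCCC[N+](=O)[O-])c1/C=N/O` gives -2.65. Compound 3 sits within the scatter of both others: its gap to compound 1 and its gap to compound 2 are each too small to count as a real difference. Among the compounds with values here, the only single-point step among the three shows a number 0.15 log units lower from compound 1 to compound 3 (within the scatter), with nitro in place of methylsulfonyl on a saturated chain carbon, three bonds along the chain from an oxygen on a saturated carbon. Compound 4 `CCS(=O)(=O)CCOCn1cc[n+](C)c1/C=N/O` is not yet measured; it differs from compound 3 in that (ethylsulfonyl in place of nitromethyl on a saturated chain carbon, two bonds along the chain from an oxygen on a saturated carbon). This change largely undoes the earlier swap, bringing a sulfonyl group back in place of a nitro group, so the step from compound 1 to compound 3 is the one that bears on it. Because that step was a number 0.15 log units lower from compound 1 to compound 3 (within the scatter), the expected step of a number 0.15 log units higher from compound 3 to compound 4 (within the scatter) is small, leaning upward if anything but not beyond the scatter. Compound 4 is therefore estimated at -2.5, within a range from -2.9 to -2.1.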

Compound 4, distribution coefficient: < -2.7
Compound 4 was reported as a limit; the forecaster's own chance of this, stated with the estimate: 5%; middle value at least 0.20 log units from the limit.
By their numbers in this assay, from the lowest: compounds 3, 1 and 2 (each within the scatter of the next). At a limit, below all of these: compound 4.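

In this assay, compound 4 carries a limit rather than a number: < -2.7. Within the data shown here, with ethyl in place of phenyl on the sulfonyl sulfur, the result is a number at least 0.31 log units lower from compound 2 to compound 4 (beyond the scatter), the first step here that clears the scatter, so the group on that sulfur can shift this read-out. The other two steps, a number at least 0.05 log units lower from compound 3 to compound 4 (that floor lies within the scatter) and a number at least 0.20 log units lower from compound 1 to compound 4 (that floor lies within the scatter), have floors within the scatter, so their true sizes stay unsettled, and all three steps are floors set by one boundary: the limit of < -2.7 in this assay, at which 1 of the 4 values shown sits.

As far as these compounds go, the true number for compound 4 remains open, and with it the full size of each step. Also open, from the compounds shown here alone, is how a longer chain on the sulfonyl sulfur, or an amine in place of the sulfonyl group, would read in this assay.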